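The source may hold more compounds than are shown below. What is called first, only, known or untested is meant among the compounds shown, and "the series" means these compounds.

Measured so far in a functional assay on QGY7701 cells (Homo sapiens) for cytotoxicity, read by MTT assay, with a stated time of 48 h; a higher number here means a weaker inhibitor, a lower number a stronger inhibitor:
compound 1 `O=c1ccoc2cc(OCc3cn(Cc4cccc(Br)c4)nn3)ccc12` gives 17600 nM;
compound 2 `O=c1ccoc2cc(OCc3cn(Cc4ccc(F)cc4)nn3)ccc12` gives 14400 nM;
compound 3 `O=c1ccoc2cc(OCc3cn(Cc4cccc(Cl)c4)nn3)ccc12` gives 28400 nM.

Compound 1 stands second highest of the three numbers; its nearest neighbour is compound 2 (a 1.2-fold lower number from compound 1 to compound 2 (0.09 log units; within the scatter)) and its furthest is compound 3 (a 1.6-fold higher number from compound 1 to compound 3 (0.21 log units; within the scatter)), both within the scatter. The remaining pair also sits within the scatter (a 2.0-fold higher number from compound 2 to compound 3 (0.29 log units; within the scatter)). On these three the series is flat: no swap at the benzyl position has yet moved this assay beyond repeat variation.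

Compound 4 `N#Cc1ccc(Cn2cc(COc3ccc4c(=O)ccoc4c3)nn2)cc1` is not yet measured. It differs from compound 1 as follows: 4-cyanophenyl in place of 3-bromophenyl on a saturated chain carbon bound to an aromatic nitrogen. For the measured compounds named here, the steps that bear on it are the two that also exchange the group on the saturated chain carbon bound to the aromatic nitrogen, from compound 1 to compound 2 and from compound 2 to compound 3, and both were within the scatter. Going by the values given here, a 4-cyanophenyl has no precedent here, so the expectation rests on that flatness alone. For compound 4 the expected step is a 1.0-fold higher number from compound 1 to compound 4 (0.01 log units; within the scatter), that is, no change beyond the scatter. The estimate for compound 4 in this assay is therefore 18000 nM, with a range from 7000 nM to 45000 nM.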

Compound 4, half-maximal inhibitory concentration: > 100000 nM
Compound 4: no number, only a limit; the forecaster's own chance of this, stated with the estimate: 10%; middle value at least 5.5-fold (0.74 log units) from the limit.
By their numbers in this assay, from the lowest: compounds 2, 1 and 3 (each within the scatter of the next). At a limit, above all of these: compound 4.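

In this assay, compound 4 gives only a limit, not a number: the limit of > 100000 nM in this assay, at which 1 of the 4 values shown sits.

The position is therefore not flat: the 3-bromophenyl, 3-chlorophenyl and 4-fluorophenyl groups stay within the scatter of one another, whereas the 4-cyanophenyl group gives an at least 5.6-fold higher number from compound 1 to compound 4 (0.75 log units; beyond the scatter), an at least 3.5-fold higher number from compound 3 to compound 4 (0.54 log units; beyond the scatter) and an at least 6.9-fold higher number from compound 2 to compound 4 (0.84 log units; beyond the scatter). Compound 2 and compound 4 differ only by cyano in place of fluoro on an aromatic carbon, which ties this loss of activity to that single exchange rather than to the shared core.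

The compounds shown leave open how far compound 4 lies past its limit. They also leave open whether the loss is particular to the nitrile or would recur with a carboxylic acid, a primary amide or an amine in its place.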